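Chloro in place of trifluoromethoxy on a fused-ring analogue

A few compounds are considered here, and "the series" means these few. Any claim that something is new, unique, unknown or untested is made for them only; others in the source may bear on it.

Of the compounds shown here, three have been tested in a functional assay on Huh-7 cells (Homo sapiens) for inhibition, read by sulforhodamine B assay, with a stated time of 72 h; a lower number here means a stronger inhibitor, a higher number a weaker inhibitor. Compound 1 `COc1ccc2cc(C(C)c3nnc4n3N=C(c3ccc(OC(F)(F)F)cc3)CS4)ccc2c1` gives 16000 nM. Among the measured compounds shown here, compound 3 `CC(C)Cc1ccc(C(C)c2n[nH]c(=S)n2N)cc1`, which carries the open form of the core, gives 23000 nM, a number that lies within the scatter of the one for compound 1. Compound 2 `CC(C)Cc1ccc(C(C)c2nnc3n2N=C(c2ccc(Cl)cc2)CS3)cc1` gives 5700 nM, a lower number than that of compound 1 and beyond the scatter; the two differ in more than one place, so only the two values themselves can be compared.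

Compound 4 `COc1ccc2cc(C(C)c3nnc4n3N=C(c3ccc(Cl)cc3)CS4)ccc2c1` has not yet been measured in this assay. It differs from compound 1 in one place: chloro in place of trifluoromethoxy on an aromatic carbon. For the measured compounds named here, no single-change step between measured compounds covers this exchange. The step from compound 1 to compound 4 is expected to be small and downward, at the edge of the scatter, at most a 1.6-fold lower number from compound 1 to compound 4 (0.20 log units; within the scatter), partly because compound 2 with its chloro group gives 5700 nM. Compound 4 is therefore estimated at 10000 nM, with a range from 4000 nM to 30000 nM.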

Compound 4, half-maximal inhibitory concentration: 5600 nM
Beside the measured number, compound 4's estimate is 1.8-fold (0.25 log units) above it; the measured number falls inside the stated range.
By their numbers in this assay, from the lowest: compounds 4 and 2 (each within the scatter of the next); then compounds 1 and 3 (each within the scatter of the next).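

The exchange of trifluoromethoxy for chloro gives the series its first single-change step in this assay, with a 2.9-fold lower number from compound 1 to compound 4 (0.46 log units; beyond the scatter), so the number can now be tied to one place rather than to compounds that differ in several. It shows that the group on this aromatic carbon, para to a large group, can shift the number beyond the scatter when the rest of compound 1 stays fixed. No measured property is available to account for the step.

This is a single pair, so the result sets no trend for the position. The compounds shown leave open how a methoxy group, an amine or a carboxylic acid would fare here, and whether the same exchange would give a step of similar size with the side group of compound 2 in place.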